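The source may hold more compounds than are shown below. What is called first, only, known or untested is meant among the compounds shown, and "the series" means these compounds.

Measured compounds:
compound 1, `N#Cc1ccccc1CN1CCC(O)(Cn2cnc3c(cnn3-c3ccc(F)cc3)c2=O)CC1`, 8100 nM
compound 2, `O=c1c2cnn(-c3ccc(F)cc3)c2ncn1CC1(O)CCN(Cc2ccc(F)cc2Cl)CC1`, 1600 nM

Among the compounds with values here, in an assay on Sf21 cells for inhibition of ubiquitin carboxyl-terminal hydrolase 7 (Homo sapiens), read by spectrophotometry, with stated times of 30 min and 2 h (a higher number here means a weaker inhibitor, a lower number a stronger inhibitor), compound 2 has the lowest of the two numbers; its nearest neighbour is compound 1, and the only measured step runs a 5.1-fold lower number from compound 1 to compound 2 (0.70 log units; beyond the scatter). Compound 3, `N#Cc1cc(Cl)ccc1CN1CCC(O)(Cn2cnc3c(cnn3-c3ccc(F)cc3)c2=O)CC1`, differs from compound 2 in one place: 4-chloro-2-cyanophenyl in place of 2-chloro-4-fluorophenyl on a saturated chain carbon bound to an amine nitrogen in a ring. Within the data shown here, this change bears directly on the single known step: it brings back the nitrile of compound 1 while keeping a chlorine, so it partly undoes the substitution that gave a 5.1-fold lower number from compound 1 to compound 2 (0.70 log units; beyond the scatter). Among the measured compounds shown here, no second measured pair shows how a chlorine and a nitrile together behave in this assay. Compound 3 is therefore expected to land between the two measured values, probably closer to compound 2 than to compound 1, and its estimated value is 3500 nM with a range of 1300 nM to 9500 nM. The expected step is a 2.2-fold higher number from compound 2 to compound 3 (0.34 log units; beyond the scatter).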

Compound 3, half-maximal inhibitory concentration: 11400 nM
Compound 3: the middle estimate sits 3.3-fold (0.51 log units) below what was measured, and the stated range ends below it.
By their numbers in this assay, from the lowest: compound 2; then compounds 1 and 3 (each within the scatter of the next).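

In this assay, the step of a 7.1-fold higher number from compound 2 to compound 3 (0.85 log units; beyond the scatter) shows that the 4-chloro-2-cyanophenyl group does not keep the lower number of the 2-chloro-4-fluorophenyl group, even though both carry a chlorine. The step of a 1.4-fold higher number from compound 1 to compound 3 (0.15 log units; within the scatter) lies within the scatter, so with the nitrile in place, chloro in place of hydrogen on this aromatic ring makes no measurable difference. Nothing available explains this result.

The compounds shown leave open whether the lower number of compound 2 depends on its chlorine, its fluorine or both together, and whether the absence of the nitrile matters on its own. They also leave open how a methoxy or trifluoromethyl group would read in place of the nitrile on this benzyl ring.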